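The compounds below may be only part of what the source reports. "The series", "measured", "known", "first", "only" and "open" are said of these compounds alone.

Measured so far in an assay on HEK293 cells for inhibition of Leucine-rich repeat serine/threonine-protein kinase 2 (Homo sapiens), with a stated time of 48 h; on this read-out higher numbers stand for weaker inhibition and lower numbers for stronger inhibition:

Compound 1, `Cc1nn(CC2(O)COC2)cc1Nc1nc(N)c2c(C#N)c(N3CCC[C@H]3C)n(C)c2n1`: 410 nM
Compound 2, `Cc1c(Nc2nc(N)c3c(C#N)c(N4CCC[C@H]4C)n(C)c3n2)cnn1CC(C)(C)O`: 280 nM
Compound 3, `Cc1nn(C)cc1Nc1nc(N)c2c(C#N)c(N3CCC[C@H]3C)n(C)c2n1`: 190 nM

Within the data shown here, compound 3 holds the lowest number of the three; its gap to compound 2 lies within the scatter, and only the step of a 2.2-fold lower number from compound 1 to compound 3 (0.33 log units; beyond the scatter) is beyond it. That step concerns the substituent on the saturated chain carbon bound to an aromatic nitrogen.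

Compound 4, `C[C@@H]1CCCN1c1c(C#N)c2c(N)nc(Nc3cn(C)nc3Cl)nc2n1C`, differs from compound 3 by chloro in place of methyl on an aromatic carbon. Among the measured compounds shown here, no measured step touches this aromatic carbon; the one step, a 2.2-fold lower number from compound 1 to compound 3 (0.33 log units; beyond the scatter), lies elsewhere and gives no guide in this assay. A step of no size beyond the scatter is therefore expected. Compound 4 is estimated at 190 nM in this assay, between 80 nM and 450 nM. The step of no change at the digits printed from compound 3 to compound 4 (within the scatter) is expected to stay within the scatter.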

Compound 4, half-maximal inhibitory concentration: 190 nM
Compound 4: the middle estimate sits on the measured number at the digits printed; measured number inside the range.
By their numbers in this assay, from the lowest: compounds 3, 4, 2 and 1 (each within the scatter of the next, the first and the last beyond it).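

In this assay, among these compounds, chloro in place of methyl on this aromatic carbon gives no change at the digits printed from compound 3 to compound 4 (within the scatter), the first reading at this position. The number therefore holds when 1,3-dimethyl-1H-pyrazol-4-yl becomes 3-chloro-1-methyl-1H-pyrazol-4-yl. No evidence is available on why the two groups read alike.

As far as these compounds go, whether hydrogen, methoxy or cyclopropyl at this carbon would read the same remains open. Also open, from the compounds shown here alone, is whether chloro would read alike with the larger groups on the ring nitrogen carried by compound 1 and compound 2.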